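Difluorophenyl Replaces Cyanophenyl on a Weakly Active Core

This account rests on a few compounds, and the source may have more. Where it says the series, first, only, none or still open, it means among the compounds named here.

The series shares an octadecyl amide attached to a five-membered ring carrying nitrogen and sulfur, with a varied group on one saturated ring carbon. Compound 1 `CCCCCCCCCCCCCCCCCCNC(=O)[C@H]1CSC(Cc2ccccc2)N1` bears a benzyl group there and in a functional assay on PC-3 cells (Homo sapiens) for antiproliferative activity, read by sulforhodamine B assay (on this read-out lower numbers stand for stronger inhibition and higher numbers for weaker inhibition), gives 16400 nM. Compound 2 `CCCCCCCCCCCCCCCCCCNC(=O)[C@H]1CSC(c2ccc(Br)cc2)N1` carries a 4-bromophenyl group; in this assay compound 2 gives 17300 nM, so that a 1.1-fold higher number from compound 1 to compound 2 (0.02 log units; within the scatter). Compound 3 `CCCCCCCCCCCCCCCCCCNC(=O)[C@H]1CSC(c2ccc(C#N)cc2)N1` carries a 4-cyanophenyl group. For compound 3 this assay reports only a limit, > 20000 nM, described by the limit of > 20000 nM in this assay, at which 1 of the 3 values shown sits. Accordingly an at least 1.2-fold higher number from compound 1 to compound 3 (0.08 log units; that floor lies within the scatter) and an at least 1.1-fold higher number from compound 2 to compound 3 (0.06 log units; that floor lies within the scatter) are known only as floors.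

Compound 4 `CCCCCCCCCCCCCCCCCCNC(=O)[C@H]1CSC(c2cc(F)cc(F)c2)N1` is the next step: 3,5-difluorophenyl in place of 4-cyanophenyl on a saturated ring carbon. The measured steps that bear on it are the three aryl exchanges above, and none of them moved the number beyond the scatter; every aryl or benzyl variant so far sits at or near the high end of the measurable range. He therefore expects no step beyond the scatter in this assay, and his estimate means that an at least 1.1-fold lower number from compound 3 to compound 4 (0.04 log units; that floor lies within the scatter). For compound 4 the expected value is 18000 nM, with an estimated range from 8000 nM to 40000 nM, and a real chance that only a limit is reported again.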

Compound 4, half-maximal inhibitory concentration: > 20000 nM
Compound 4: no number, only a limit; the forecaster's own chance of this, stated with the estimate: 45%; middle value at least 1.1-fold (0.04 log units) from the limit.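

In this assay compound 4, like compound 3, gives no number, only a limit: the limit of > 20000 nM in this assay, at which 2 of the 4 values shown sit. For the compounds shown here, the step between these two compounds cannot be read, so this exchange of 4-cyanophenyl for 3,5-difluorophenyl on a saturated ring carbon shows only that a second aryl group, one without the nitrile and carrying two fluorines, also fails to give a measured value. Against the two compounds that do have numbers, the result is an at least 1.1-fold higher number from compound 2 to compound 4 (0.06 log units; that floor lies within the scatter) and an at least 1.2-fold higher number from compound 1 to compound 4 (0.08 log units; that floor lies within the scatter), so neither floor separates compound 4 from them, and no variant at this position yet stands apart from the others beyond the scatter.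

The compounds shown leave open whether a different kind of group on this ring carbon, such as 4-hydroxyphenyl, 4-aminophenyl or 4-carboxyphenyl, would bring the number down beyond the scatter. As far as these compounds go, the octadecyl chain is common to all four compounds, and whether a shorter chain, such as dodecyl, on the same amide would change the reading also remains open.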